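Swapping a fluorophenyl for a cyclohexenyl on the alkyne

The compounds below may be only part of what the source reports. "The series", "measured", "known", "first", "only" and "open" are said of these compounds alone.

Compound 3, `NC(=O)c1nc(C#Cc2ccc(F)cc2)n(COCCO)n1`, stands at the ceiling of what was tested: in an ADME assay on Huh-5-2 cells (Homo sapiens) for cytotoxicity (a lower number here means that less compound is tolerated, a higher number that more compound is tolerated), compound 3 gives > 50 ug/mL, which is a limit of the assay rather than a measured number. Its companions share the same core. Compound 1, `COc1ccc(C#Cc2nc(C(N)=O)nn2COCCO)cc1`, carries a methoxy on the aromatic ring, and in this assay compound 1 gives > 50 ug/mL, again a limit. Compound 2, `CCCCCc1ccc(C#Cc2nc(C(N)=O)nn2COCCO)cc1`, carries a pentyl instead, and in this assay compound 2 gives 25 ug/mL. The step of an at least 2.0-fold lower number from compound 1 to compound 2 (0.30 log units; that floor lies within the scatter) and the step of an at least 2.0-fold higher number from compound 2 to compound 3 (0.30 log units; that floor lies within the scatter) are the only readable ones, and both sit at their floors; the step that the two limits leave unreadable from compound 1 to compound 3 cannot be read because of the limit of > 50 ug/mL in this assay, at which 2 of the 3 values shown sit.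

Compound 4, `NC(=O)c1nc(C#CC2=CCCCC2)n(COCCO)n1`, differs from compound 3 by cyclohex-1-en-1-yl in place of 4-fluorophenyl on a triple-bonded carbon. Among the compounds with values here, none of the measured steps touches this kind of change, since all of them swap one substituent on the aromatic ring rather than the ring itself. With two of three compounds at the limit, the expectation for compound 4 is that it also remains tolerated up to the limit, so the estimated step of a number no higher from compound 3 to compound 4 (the limit leaves the size open) is none beyond the scatter. The estimate for compound 4 is therefore 50 ug/mL, within 25 ug/mL to 100 ug/mL.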

Compound 4, half-maximal cytotoxic concentration: > 50 ug/mL
Compound 4: a limit, no number; the forecaster's own chance of this, stated with the estimate: 60%; the middle value sits exactly at the limit.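

In this assay compound 4 gives > 50 ug/mL as a limit of the assay, not a number. Within the data shown here, compound 3 sits at the same limit, so no step between compound 3 and compound 4 can be read: the limit of > 50 ug/mL in this assay, at which 3 of the 4 values shown sit. The compounds shown leave open whether cyclohex-1-en-1-yl in place of 4-fluorophenyl changes the tolerated concentration at all.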